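This account rests on a few compounds, and the source may have more. Where it says the series, first, only, none or still open, it means among the compounds named here.

Compound 1 `COc1ccc(CN(C(=O)CSc2nc3ccccc3s2)c2cc(OC)c(OC)c(OC)c2)cc1F` is the starting point, and in a functional assay on HCT-116 cells (Homo sapiens) for antiproliferative activity, read by MTT assay, with a stated time of 48 h (on this read-out lower numbers stand for stronger inhibition and higher numbers for weaker inhibition), compound 1 gives 1830 nM. Among the two compounds measured here, compound 1 has the lowest number. Compound 2 `COc1ccc(CN(C(=O)CSc2nc3ccccc3s2)c2cc(OC)c(OC)c(OC)c2)cc1C` carries a methyl in place of the fluoro, and in this assay compound 2 gives 17100 nM, which is a 9.3-fold higher number from compound 1 to compound 2 (0.97 log units; beyond the scatter). Compound 3 `COc1ccc(CN(C(=O)CSc2nc3ccccc3s2)c2cc(OC)c(OC)c(OC)c2)cc1C(F)(F)F` has not yet been measured. It differs from compound 1 as follows: trifluoromethyl in place of fluoro on an aromatic carbon. Among the measured compounds shown here, the only measured step that bears on this change is the one from compound 1 to compound 2, where a different group took the place of the same fluoro and the number rose well beyond the scatter. A similar rise is therefore expected in this assay for compound 3, so the estimated step is a 4.4-fold higher number from compound 1 to compound 3 (0.64 log units; beyond the scatter). Compound 3 is expected to give about 8000 nM, within a range from 2500 nM to 25000 nM.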

Compound 3, half-maximal inhibitory concentration: > 80000 nM
Compound 3 was reported as a limit; the forecaster's own chance of this, stated with the estimate: 10%; middle value at least 10-fold (1.00 log units) from the limit.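

Swapping the fluoro for trifluoromethyl gives an at least 43-fold higher number from compound 1 to compound 3 (1.64 log units; beyond the scatter), so carrying fluorine atoms at this position does not by itself preserve the activity of compound 1. Among the compounds shown here, the change from methyl to trifluoromethyl adds a further rise, an at least 4.6-fold higher number from compound 2 to compound 3 (0.67 log units; beyond the scatter), and this gives the first ranking of three groups at one position: fluoro has the lowest number, then methyl, then trifluoromethyl. From the compounds shown here alone, compound 3 is reported only as a limit in this assay, so its true number and the true size of both steps remain unknown: the limit of > 80000 nM in this assay, at which 1 of the 3 values shown sits.

The compounds shown leave open whether a chloro, a hydroxyl or an amine at this position would match or improve on fluoro. They also do not say whether this ranking would hold for the same groups placed elsewhere on the ring.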